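The compounds below may be only part of what the source reports. "The series", "measured", "known", "first", "only" and "open" are said of these compounds alone.

Three compounds share a core built around a six-membered aromatic ring with one nitrogen. Compound 1 `Oc1cccc(-c2cc(-c3ccsc3)cc(-c3ccccc3O)n2)c1` and compound 2 `Oc1ccc(-c2cc(-c3ccsc3)cc(-c3ccccc3O)n2)cc1` differ by 4-hydroxyphenyl in place of 3-hydroxyphenyl on an aromatic carbon. In a functional assay on T47D cells (Homo sapiens) for cytotoxicity, read by CCK-8 assay (on this read-out lower numbers stand for stronger inhibition and higher numbers for weaker inhibition), compound 1 gives only a limit of the assay, > 50000 nM. In this assay compound 2 likewise gives only a limit, > 50000 nM. The step that the two limits leave unreadable from compound 1 to compound 2 therefore cannot be read, because of the limit of > 50000 nM in this assay, at which 2 of the 3 values shown sit. Compound 3 `Oc1cccc(-c2cc(-c3ccoc3)cc(-c3cccc(O)c3)n2)c1` gives 2590 nM in this assay; the difference between its core and that of compound 1 is not broken down here. Compound 4 `Oc1ccc(-c2cc(-c3ccoc3)cc(-c3cccc(O)c3)n2)cc1` differs from compound 3 by 4-hydroxyphenyl in place of 3-hydroxyphenyl on an aromatic carbon, the same kind of change as from compound 1 to compound 2, but here the place is meta to a 3-hydroxyphenyl group and meta to a furan-3-yl group rather than meta to a 2-hydroxyphenyl group and a thiophen-3-yl group. Since the earlier step is unreadable, only a small step is expected, a 1.5-fold higher number from compound 3 to compound 4 (0.19 log units; within the scatter). Compound 4 is estimated at 4000 nM, between 1000 nM and 20000 nM.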

Compound 4, half-maximal inhibitory concentration: 2610 nM
Beside the measured number, compound 4's estimate is 1.5-fold (0.19 log units) above it; low and high end bracket the measured number.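

In this assay, 4-hydroxyphenyl in place of 3-hydroxyphenyl gives a 1.0-fold higher number from compound 3 to compound 4 (0.00 log units; within the scatter), so on this core the two compounds cannot be told apart. Whether the change behaves the same way on the core of compound 1 cannot be said, because neither compound on that core gives a number and the step there cannot be read: the limit of > 50000 nM in this assay, at which 2 of the 4 values shown sit. This leaves one readable pair, which describes one core and sets no rule for others.

An amine or a carboxylic acid in place of the hydroxy group on these phenyl rings remains untested among the compounds shown. Going by these compounds, what a furan-3-yl group does in place of a thiophen-3-yl group, with all else held the same, also stays open.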